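A few compounds are considered here, and "the series" means these few. Any claim that something is new, unique, unknown or untested is made for them only; others in the source may bear on it.

Measured compounds in an in vivo ADME assay on the whole organism for metabolic stability, with Rattus norvegicus as the target, using cassette dosing; a higher number here means that the compound lasts longer, a lower number that the compound disappears faster:
compound 1 `CO[C@]1(C)C[C@H](C(=O)Nc2ccc(-n3ccccc3=O)cc2F)N(C(=O)Nc2ccc(Cl)cc2)C1` gives 1.7 h;
compound 2 `CC[C@@]1(O)C[C@H](C(=O)Nc2ccc(-n3cccc(C)c3=O)cc2F)N(C(=O)Nc2ccc(Cl)cc2)C1` gives 5.2 h;
compound 3 `O=C(Nc1ccc(-n2ccccc2=O)cn1)[C@H]1C[C@](O)(c2ccccc2)CN1C(=O)Nc1ccc(Cl)cc1` gives 2.9 h.

Compound 3 sits between compound 1 and compound 2 on the half-life scale, and both gaps lie within the usual scatter of this assay, so the three numbers cannot be separated with confidence. Compound 4 `Cc1cccc([C@@]2(O)C[C@H](C(=O)Nc3ccc(-n4ccccc4=O)cn3)N(C(=O)Nc3ccc(Cl)cc3)C2)c1` has not yet been measured. It differs from compound 3 by methyl in place of hydrogen on an aromatic carbon. Going by the values given here, no matched pair among the measured compounds isolates such a change, so the direction of the step in this assay is open, and a step within the scatter is the most likely outcome. On that footing compound 4 is expected to give 2.5 h, with a range from 1.2 h to 5 h. That implies an expected step of a 1.2-fold lower number from compound 3 to compound 4 (0.06 log units; within the scatter).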

Compound 4, half-life: 1.4 h
Estimate against measurement, compound 4: 1.8-fold (0.25 log units) above; the measured number falls inside the stated range.
By their numbers in this assay, from the lowest: compounds 4, 1, 3 and 2 (each within the scatter of the next, the first and the last beyond it).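

Phenyl to 3-methylphenyl gives the first comparison in this assay between compounds that differ in one place: methyl in place of hydrogen on an aromatic carbon, meta to a large group, brings a 2.1-fold lower number from compound 3 to compound 4 (0.32 log units; beyond the scatter). The half-life thus responds to this single added carbon at this position, although the step is modest and rests on one pair. No available evidence bears on the reason for the step. Going by these compounds, whether an amine or a carboxylic acid on the same carbon would move the half-life the same way remains open, as does the effect of methyl elsewhere on this ring.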